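This account rests on a few compounds, and the source may have more. Where it says the series, first, only, none or still open, it means among the compounds named here.

Three aryl groups hang from the shared core in this series. Compound 1 `Oc1ccc(-c2cc(-c3cccc(Cl)c3)nc(-c3ccccn3)c2)cc1` carries a hydroxyphenyl group, a chlorophenyl group and a pyridin-2-yl group, and in a functional assay on DU-145 cells (Homo sapiens) for cytotoxicity, read by CCK-8 assay and cell counting, with a stated time of 2 days (a higher number here means a weaker inhibitor, a lower number a stronger inhibitor), compound 1 gives 35200 nM. Compound 3 `Oc1ccc(-c2cc(-c3cccs3)nc(-c3ccccc3Cl)c2)cc1` carries a thiophene and a chlorophenyl group in place of the pyridine, and in this assay compound 3 gives 4190 nM. Compound 2 `Oc1cccc(-c2cc(-c3cccc(Cl)c3)nc(-c3ccccn3)c2)c1` has no result in this assay; there compound 2 is recorded as "not determined" (no result reported), so it stands on no number at all.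

Compound 4 `Oc1cccc(-c2cc(-c3ccsc3)nc(-c3cccc(Cl)c3)c2)c1` differs from compound 2 by thiophen-3-yl in place of pyridin-2-yl on an aromatic carbon. Among the measured compounds shown here, because compound 2 gives no number, the size of this step cannot be read from the two compounds; the only anchors are compound 1, at 35200 nM, and compound 3, at 4190 nM. Of the two measured compounds, the thiophene-bearing compound 3 is the stronger, so a move toward the lower end of that span is expected for compound 4, though a difference beyond the usual scatter is not assured. Compound 4 is therefore estimated at 8000 nM, within a range from 2000 nM to 40000 nM.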

Compound 4, half-maximal inhibitory concentration: 3330 nM
Compound 4: middle estimate off by 2.4-fold (0.38 log units), on the high side, within the range that was stated.
By their numbers in this assay, from the lowest: compounds 4 and 3 (each within the scatter of the next); then compound 1.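

Among the compounds shown here, compound 2 has no number in this assay, so no step to compound 4 can be read. The compounds shown leave open how far replacing pyridin-2-yl with thiophen-3-yl on its own shifts the value in this assay and in which direction. Nothing shown here gives a measured explanation for these values.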